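This account rests on a few compounds, and the source may have more. Where it says the series, first, only, none or still open, it means among the compounds named here.

In a functional assay on brain (Rattus norvegicus, strain Wistar) for inhibition (on this read-out higher numbers stand for weaker inhibition and lower numbers for stronger inhibition), the measured compounds are:
compound 1 `CCCc1ccc(-c2c(C)[nH]c(=O)n2C)cc1`, 21500 nM;
compound 2 `Cc1[nH]c(=O)n(C)c1-c1ccc(OC(C)C)cc1`, 20400 nM;
compound 3 `CCCc1ccc(-c2c(C)[nH]c(=O)n2C2CCCCC2)cc1`, 13900 nM.

All three numbers lie close together; the known steps are a 1.1-fold lower number from compound 1 to compound 2 (0.02 log units; within the scatter) and a 1.5-fold lower number from compound 1 to compound 3 (0.19 log units; within the scatter), both small. Compound 4 `Cc1[nH]c(=O)n(C2CCCCC2)c1-c1ccc(OC(C)C)cc1` has not been measured. It differs from compound 3 by isopropoxy in place of propyl on an aromatic carbon. The same kind of change has already been made once, from compound 1 to compound 2: isopropoxy in place of propyl on an aromatic carbon. The two cores are not identical; they differ by cyclohexyl in place of methyl on an aromatic nitrogen. The surroundings of the change are also described a little differently: in compound 1 the group sits para to a group of 8 heavy atoms, in compound 3 para to a large group, so this counts as the same kind of change rather than the same one. For compound 4 the expected step is a 1.1-fold lower number from compound 3 to compound 4 (0.03 log units; within the scatter), small like the earlier one, because a 1.1-fold lower number from compound 1 to compound 2 (0.02 log units; within the scatter) stayed within the scatter. Compound 4 is therefore estimated at 13000 nM in this assay, expected to fall between 5000 nM and 35000 nM.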

Compound 4, half-maximal inhibitory concentration: 13000 nM
Beside the measured number, compound 4's estimate shows no gap at the digits printed, within the range that was stated.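

In this assay, among the compounds shown here, isopropoxy in place of propyl gives a 1.1-fold lower number from compound 3 to compound 4 (0.03 log units; within the scatter), and this small step carries over from one core to the other with no real change in size: the same change on two cores in this assay, a 1.1-fold lower number (0.02 log units; within the scatter) from compound 1 to compound 2 and a 1.1-fold lower number (0.03 log units; within the scatter) from compound 3 to compound 4, 1.0-fold (0.01 log units) apart, within the scatter of two such steps Read the other way, cyclohexyl in place of methyl on an aromatic nitrogen gives a 1.6-fold lower number from compound 2 to compound 4 (0.20 log units; within the scatter), and this step also matches its earlier counterpart: the same change on two cores in this assay, a 1.5-fold lower number (0.19 log units; within the scatter) from compound 1 to compound 3 and a 1.6-fold lower number (0.20 log units; within the scatter) from compound 2 to compound 4, 1.0-fold (0.01 log units) apart, within the scatter of two such steps Across these four compounds, each change behaves the same on either core, but every step stays within the scatter, so this shows only that neither change moved the number measurably here, not that either one improves inhibition or that a change with a large effect would carry over as cleanly.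

From the compounds shown here alone, it remains open whether another group on the aromatic carbon, such as an amine, a carboxylic acid or a longer chain, would shift the number beyond the scatter. The same question stands for the aromatic nitrogen, where only methyl and cyclohexyl appear.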